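Swapping chloro for methoxy on an allenic amine MAO inhibitor

The source may report more compounds than this note shows. Statements on the series, on what has been measured and on what is new or still open speak of the compounds shown alone.

Measured so far:
Compound 1, `C=C=C(Cc1ccccc1)CN(C)C`: > 100000 nM
Compound 2, `C=C=C(CN)Cc1ccc(Cl)cc1`: 40 nM

Within the data shown here, in an assay on isolated protein for inhibition of Monoamine oxidase (Rattus norvegicus) (a higher number here means a weaker inhibitor, a lower number a stronger inhibitor), compound 2 gives 40 nM, the only true number among the two values shown. For compound 1 the value in this assay is a limit of the assay and not a number, > 100000 nM. Compound 1 therefore sits at the limit of > 100000 nM in this assay, at which 1 of the 2 values shown sits. Among the measured compounds shown here, no pair of measured compounds differs in only one place, so no measured step is available to guide the next move.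

Compound 3, `C=C=C(CN)Cc1ccc(OC)cc1`, is the untested neighbour of compound 2. The change is methoxy in place of chloro on an aromatic carbon. A single swap of one small group on the aromatic ring is expected to shift this assay modestly, if at all; a small loss of potency is expected, roughly the step of a 3.8-fold higher number from compound 2 to compound 3 (0.57 log units; beyond the scatter), though a result within the scatter would not surprise. Compound 3 is thus estimated to give 150 nM in this assay, with a likely range from 30 nM to 800 nM.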

Compound 3, half-maximal inhibitory concentration: 580 nM
For compound 3 the middle estimate is 3.9-fold (0.59 log units) below the measured one; low and high end bracket the measured number.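

In this assay, the swap of chloro for methoxy on an aromatic carbon produces a 15-fold higher number from compound 2 to compound 3 (1.16 log units; beyond the scatter). This large step, well beyond the usual scatter, shows that this place on the ring is sensitive to which small group it carries, even though only one heavy atom leaves and two enter. Nothing shown here explains why the step is this large.

The compounds shown leave open whether a smaller group, such as fluoro or methyl, at the same place would keep a number close to that of compound 2 or move towards that of compound 3. Among these compounds, also open is the contribution of the dimethylamino group of compound 1, which differs from compound 2 in more than one place, so no single step isolates it.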